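The source may hold more compounds than are shown below. What is called first, only, known or untested is meant among the compounds shown, and "the series" means these compounds.

Values in a functional assay on U2OS cells for antagonist activity at C-X-C chemokine receptor type 3 (Homo sapiens), read by beta-arrestin recruitment (a higher number here means a weaker inhibitor, a lower number a stronger inhibitor), for the two measured compounds:

- compound 1, `Cc1nc(C)n(CC(=O)N2CCN(c3sc(C(F)(F)F)nc3-c3cnc(OC4CCC4)nc3)C[C@H]2C)n1`: 78 nM
- compound 2, `CCCc1ncc(-c2nc(C(F)(F)F)sc2N2CCN(C(=O)Cn3nc(C)nc3C)[C@H](C)C2)cn1`: 258 nM

Compound 2 holds the higher of the two numbers; the step of a 3.3-fold higher number from compound 1 to compound 2 (0.52 log units; beyond the scatter) separates it from compound 1, and it is beyond the scatter.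

Compound 3 is `COc1ccc(-c2nc(C(F)(F)F)sc2N2CCN(C(=O)Cn3nc(C)nc3C)[C@H](C)C2)cn1`. It differs from compound 2 in one place: 6-methoxypyridin-3-yl in place of 2-propylpyrimidin-5-yl on an aromatic carbon.

Among the measured compounds shown here, only one measured step bears on this change, a 3.3-fold higher number from compound 1 to compound 2 (0.52 log units; beyond the scatter), in which an alkyl chain took the place of an alkoxy group on the same ring and the number rose. The change from compound 2 to compound 3 runs the other way, alkyl giving way to an alkoxy group, so the number is expected to fall rather than rise. For the measured compounds named here, the change in the ring itself, from one with 2 hetero atoms to one with 1 hetero atom, has no measured counterpart, and the alkoxy group entering is smaller than the one in compound 1; the expected step of a 1.7-fold lower number from compound 2 to compound 3 (0.24 log units; within the scatter) is therefore kept smaller than the measured step, with a wide range. Compound 3 is estimated at 150 nM, between 50 nM and 500 nM.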

Compound 3, half-maximal inhibitory concentration: 1170 nM
Estimate against measurement, compound 3: 7.8-fold (0.89 log units) below; measured number above the stated range.
By their numbers in this assay, from the lowest: compound 1; then compound 2; then compound 3.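

In this assay, 6-methoxypyridin-3-yl in place of 2-propylpyrimidin-5-yl gives a 4.5-fold higher number from compound 2 to compound 3 (0.66 log units; beyond the scatter) and so an alkoxy group on this aromatic ring does not by itself bring the number down; the earlier pair, which had suggested that it might, does not carry over to this change. Set against 2-(cyclobutyloxy)pyrimidin-5-yl, the same entering group gives a 15-fold higher number from compound 1 to compound 3 (1.18 log units; beyond the scatter) and leaves compound 3 with the highest number of the three, so the group on this carbon of the five-membered ring, next to the ring nitrogen, moves the number well beyond the scatter even among groups of similar heavy-atom count. Nothing available here accounts for the rise.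

The step changes the ring and its substituent at once, and a 2-methoxypyrimidin-5-yl or a 6-(cyclobutyloxy)pyridin-3-yl group would be needed to tell which of the two carries it. Going by these compounds, how an amine or a longer alkoxy chain on the same ring would read in this assay also stays open.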